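Swapping a carbamate for a phenyltriazole on the pyrrolidine

This account rests on a few compounds, and the source may have more. Where it says the series, first, only, none or still open, it means among the compounds named here.

Measured compounds:
Compound 1, `CC(=O)N[C@@H]1CCN(c2cc(C)nn3c(-c4ccc(OC(F)(F)F)cc4)c(C)nc23)C1`, in an ADME assay on microsomes from liver (Mus musculus) for metabolic stability, read by LC-MS, with NADPH named in the record, with a stated time of 60 min, tested at 1 uM, in the absence of a further agent (on this read-out higher numbers stand for a more stable compound and lower numbers for a less stable compound), compound 1 gives > 95%, a limit of the assay.
Compound 2, `COc1ccc(-c2c(C)nc3c(N4CC[C@@H](NC(=O)Oc5cccc(C)c5)C4)cc(C)nn23)cc1OC`; in this assay compound 2 gives > 95%, a limit.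
Compound 3, `COc1ccc(-c2c(C)nc3c(N4CC[C@@H](NC(=O)Oc5ccc6ccccc6c5)C4)cc(C)nn23)cc1OC`; in this assay compound 3 gives > 95%, also a limit.

Compound 2 therefore stands only at a limit, as do the two other measured compounds; all three sit at the limit of > 95% in this assay, at which 3 of the 3 values shown sit. Within the data shown here, the one measured step that changes a single group, a step that the two limits leave unreadable from compound 2 to compound 3, is unreadable in size for that reason, so the values give no sense of how large a change in this part of the molecule can be.

Compound 4, `COc1ccc(-c2c(C)nc3c(N4CC[C@@H](n5cc(-c6ccccc6)nn5)C4)cc(C)nn23)cc1OC`, differs from compound 2 by 4-phenyl-1H-1,2,3-triazol-1-yl in place of ((3-methylphenoxy)carbonyl)amino on a saturated ring carbon. Among the measured compounds shown here, no measured step bears directly on this exchange, and the single measured step is itself unreadable, so the expectation rests only on the fact that every compound so far has sat at the limit. Compound 4 is expected to remain a stable compound, with an estimated value of 90% and a range from 70% to 98%. The expected step of a number at least 5 percentage points lower from compound 2 to compound 4 (that floor lies within the scatter) is therefore estimated to lie within the usual scatter.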

Compound 4, percent of the compound remaining: "unstable" (no number reported)
Compound 4 has no reported number here; no gap can be computed for the estimate.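

In this assay compound 4 is recorded as "unstable" (no number reported), so no step can be read between compound 2 and compound 4. Compound 2 stands only at a limit, as do most of the compounds shown: the limit of > 95% in this assay, at which 3 of the 4 values shown sit. The compounds shown leave open how large the change is when 4-phenyl-1H-1,2,3-triazol-1-yl replaces ((3-methylphenoxy)carbonyl)amino.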